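Removing the chloro group from an inactive pyrazole sulfone

The source may hold more compounds than are shown below. What is called first, only, known or untested is meant among the compounds shown, and "the series" means these compounds.

Compound 1 `O=S(=O)(CC1=NCCO1)c1c(-c2ccccc2)nn(-c2ccccc2)c1-c1ccccc1` reaches 57.3% in a functional assay, tested at 75 ug/mL; on this read-out lower numbers stand for a weaker effect and higher numbers for a stronger effect at the one concentration tested. Compound 2 `O=S(=O)(CC1=NCCO1)c1n[nH]cc1-c1ccc(Cl)cc1`, which carries a smaller core, is reported in this assay as "not active" (no number reported), so no single number marks where it stands. Compound 3 `O=S(=O)(CC1=NCCO1)c1n[nH]cc1-c1ccccc1` is the not yet measured partner of compound 2, and the change between them is hydrogen in place of chloro on an aromatic carbon. Among the compounds with values here, with no measured pair showing this change, no step beyond the scatter is expected in this assay, in either direction. Compound 3 is therefore expected to give about 10% in this assay, within a range from 0% to 30%.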

Compound 3, a percentage reported as activity, at one concentration (the size of the read-out at that concentration, not a potency): 55.6%
For compound 3 the middle estimate is 45.6 percentage points below the measured one; measured number outside the range, above it.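

Within the data shown here, compound 2 has no number in this assay and compound 3 has one, and no step between them can be read. The compounds shown leave open how much the chloro group changes this read-out. Nothing shown here explains the result.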